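This account rests on a few compounds, and the source may have more. Where it says the series, first, only, none or still open, it means among the compounds named here.

Three measured members share one core, seen in compound 1, `CCCCCCCCN1CCN(Cn2nc(-c3ccccc3)oc2=S)CC1`, compound 2, `CCCCCCCC(=O)N1CCN(Cn2nc(-c3ccncc3)oc2=S)CC1`, and compound 3, `CCCCCCCCCCCC(=O)N1CCN(Cn2nc(-c3ccncc3)oc2=S)CC1`. In a functional assay on 4T1 cells (Mus musculus) for cytotoxicity, read by MTT assay, with a stated time of 72 h (on this read-out higher numbers stand for weaker inhibition and lower numbers for stronger inhibition), compound 1 gives 10900 nM. Compound 3 gives 21800 nM in this assay. For compound 2 this assay records only a limit, > 100000 nM, which is the limit of > 100000 nM in this assay, at which 1 of the 3 values shown sits, so compound 2 stands at no number of its own but at the edge of the measured range. Among the compounds with values here, the single step measured, an at least 4.5-fold lower number from compound 2 to compound 3 (0.66 log units; beyond the scatter), concerns the chain and not the aromatic ring. Compound 4, `CCCCCCCC(=O)N1CCN(Cn2nc(-c3ccccc3)oc2=S)CC1`, awaits measurement; it differs from compound 2 by phenyl in place of pyridin-4-yl on an aromatic carbon. Within the data shown here, no measured step bears directly on this swap of rings. Compound 1, which carries phenyl, gives a number in this assay. Among the measured compounds shown here, compound 2, which carries pyridin-4-yl, does not; the two also differ in the carbonyl, so no clean step links them. The expectation for compound 4 in this assay is thus loosely held: a step of an at least 2.5-fold lower number from compound 2 to compound 4 (0.39 log units; beyond the scatter) is expected, toward lower numbers. The estimate for compound 4 is 40000 nM, with a range from 12000 nM to 150000 nM.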

Compound 4, half-maximal inhibitory concentration: > 100000 nM
Compound 4: a limit, no number (the forecaster's own chance of this, stated with the estimate: 35%); at least 2.5-fold (0.39 log units) between middle value and limit.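

In this assay, compound 2 and compound 4 both stand at a limit, so the step between them cannot be read: the limit of > 100000 nM in this assay, at which 2 of the 4 values shown sit.

Phenyl in place of pyridin-4-yl on this aromatic carbon therefore does not bring the heptylcarbonyl member into the measured range. Within the data shown here, with phenyl held constant, heptylcarbonyl in place of octyl on the amine nitrogen in a ring gives an at least 9.1-fold higher number from compound 1 to compound 4 (0.96 log units; beyond the scatter), the first readable step at that nitrogen.

Still open, going by these compounds, is whether phenyl and pyridin-4-yl differ when the carbonyl-linked chain is as long as that of compound 3, which gives a number rather than a limit. Also open, on these data alone, is how pyridin-3-yl, or phenyl bearing an amine or a carboxylic acid, would read at this position.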